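A few compounds are considered here, and "the series" means these few. Any claim that something is new, unique, unknown or untested is made for them only; others in the source may bear on it.

Working notes on the series. In an in vivo ADME assay on the whole organism for pharmacokinetics, with Canis familiaris (Canis lupus familiaris) as the target, at a dose of 0.6 mg/kg by the oral route (a higher number here means that a larger share of the oral dose reaches the circulation, a lower number that a smaller share of the oral dose reaches the circulation), compound 1 (`Cc1ccc([C@H](C(=O)N(C)C)N2C(=O)[C@@H](C3Cc4ccccc4C3)NC(=O)[C@H]2CC(C)C)cn1`) gives 26% and compound 2 (`CC[C@H](C)[C@@H]1C(=O)N[C@H](C2Cc3ccccc3C2)C(=O)N1[C@@H](C(=O)N(C)C)c1ccc(C)nc1C`) gives 44%. Compound 2 therefore holds the higher of the two numbers, and its gap to compound 1 lies beyond the scatter. Going by the values given here, these two compounds differ in more than one place, so the gap cannot be assigned to any single group, and the series has no measured step at one place.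

Compound 3 (`CC[C@H](C)[C@@H]1C(=O)N[C@H](C2Cc3ccccc3C2)C(=O)N1[C@@H](C(=O)N(C)C)c1ccc(C)[n+]([O-])c1`) differs from compound 2 at one place only. The 2,6-dimethylpyridin-3-yl group, on a saturated chain carbon bound to an amide-type nitrogen in a ring and a carbonyl carbon, is exchanged: a group of 8 heavy atoms (6 carbon, 1 nitrogen, 1 oxygen; one six-membered aromatic ring with 1 hetero atom) in place of a group of 8 heavy atoms (7 carbon, 1 nitrogen; one six-membered aromatic ring with 1 hetero atom), on a saturated chain carbon bound to an amide-type nitrogen in a ring and a carbonyl carbon.

The data hold no comparison for the entering group, so the expectation in this assay is a judgement with a wide range. A fall beyond the scatter is expected, to a level near or under that of compound 1 at 26%. The expected size is a number 24 percentage points lower from compound 2 to compound 3 (beyond the scatter). For compound 3 the estimate is 20%, with an expected range of 6% to 40%.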

Compound 3, oral bioavailability: 11%
Compound 3: the middle estimate sits 9 percentage points above what was measured; measured number inside the range.
By their numbers in this assay, from the lowest: compound 3; then compound 1; then compound 2.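

Going by these compounds alone, this exchange at the saturated chain carbon bound to an amide-type nitrogen in a ring and a carbonyl carbon gives the first step that can be read at one place, and in this assay it is large: a number 33 percentage points lower from compound 2 to compound 3 (beyond the scatter). Oral bioavailability in the dog therefore depends strongly on the aromatic group at this position, even though the leaving and entering groups match in heavy-atom total, six-membered aromatic ring with 1 hetero atom, hydrogen-bond donor and acceptor counts, and lack of net charge, and differ in composition, with 6 carbon, 1 nitrogen and 1 oxygen in place of 7 carbon and 1 nitrogen. No measurement shown here bears on the cause of this step.

Within the data shown here, the single step cannot separate the contributions of the two structural differences within the exchanged group, so the share of the fall tied to either one remains unresolved. It also leaves open how a phenyl ring, or a pyridine carrying a methoxy group or a fluorine atom, would behave at this position on the core of compound 2.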